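The source may hold more compounds than are shown below. What is called first, only, known or untested is meant among the compounds shown, and "the series" means these compounds.

In a functional assay on K562 cells (Homo sapiens) for cytotoxicity, read by MTT assay, with a stated time of 48 h (a lower number here means a stronger inhibitor, a higher number a weaker inhibitor), compound 1 (`CCOC(=O)[C@@]1(C(=O)Nc2ccccc2)C[C@@H]1c1cc(OC)c(OC)c(OC)c1`) gives > 100000 nM, a limit of the assay rather than a number. Compound 2 (`CCOC(=O)C1(C(=O)Nc2ccccc2)CC1c1cc(OC)c(OC)c(OC)c1`), the same structure drawn without defined configuration, gives > 100000 nM; > 100000 nM (2 entries), which is likewise a limit. Neither result therefore offers a measured potency to build on.

Compound 3 (`CCOC(=O)[C@]1(C(=O)Nc2ccccc2)C[C@H]1c1cc(OC)c(OC)c(OC)c1`) changes only the configuration of compound 1: the two compounds have the same atoms and bonds and differ only in configuration as drawn: 2 of 2 stereo elements differ (all stereocentres are inverted: mirror images); a stereocentre at a saturated ring carbon is drawn S in compound 1 and R in compound 3; a stereocentre at a saturated ring carbon is drawn R in compound 1 and S in compound 3. The two compounds are mirror images, with the same atoms and bonds, and each stereocentre at a saturated ring carbon is inverted.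

The expectation rests on compound 2, whose result of > 100000 nM; > 100000 nM (2 entries) is also a limit, and it points to no change beyond the scatter. The expected step is a step that the limit leaves unreadable from compound 1 to compound 3, and compound 3 will most likely stay at the limit. For compound 3, the estimated value is 120000 nM, with an expected range of 50000 nM to 300000 nM.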

Compound 3, half-maximal inhibitory concentration: > 100000 nM
Compound 3 gave a limit, no number; the forecaster's own chance of this, stated with the estimate: 85%; the middle value does not contradict the limit.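

In this assay, among the compounds shown here, compound 3 gives > 100000 nM, a limit and not a number, and with compound 1 also at a limit, no step between these mirror images can be read. The compounds shown leave open whether configuration affects potency in this assay at all.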